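The source may report more compounds than this note shows. Statements on the series, on what has been measured and on what is new or still open speak of the compounds shown alone.

Working notes on the series. The shared core of compound 1 `COc1ccc(-c2ccc(COCCCCCN3C[C@H](O)[C@@H](O)[C@H](O)[C@H]3CO)cc2)cc1` carries a methoxy-substituted biaryl; in an assay on isolated protein for inhibition of ceramide glucosyltransferase (Homo sapiens) (a higher number here means a weaker inhibitor, a lower number a stronger inhibitor), compound 1 gives 25 nM. Going by the values given here, compound 2 `N#Cc1ccc(-c2ccc(COCCCCCN3C[C@H](O)[C@@H](O)[C@H](O)[C@H]3CO)cc2)cc1` replaces that methoxy with a nitrile, and in this assay compound 2 gives 150 nM, the highest number of the three measured; the step of a 6.0-fold higher number from compound 1 to compound 2 (0.78 log units; beyond the scatter) is the only measured step that touches the substituent on the distal ring. Compound 3 `OC[C@@H]1[C@@H](O)[C@H](O)[C@@H](O)CN1CCCCCOCc1ccc(-c2cc(C(F)(F)F)cc(C(F)(F)F)c2)cc1`, with a bis(trifluoromethyl)phenyl at the same end, gives 20 nM in this assay; no step to compound 2 is listed, and the two values simply show compound 3 at the lower end and compound 2 at the upper end of the set.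

Compound 4 `OC[C@@H]1[C@@H](O)[C@H](O)[C@@H](O)CN1CCCCCOCc1ccc(-c2ccnc(F)c2)cc1` is not yet measured. The change from compound 2 is 2-fluoropyridin-4-yl in place of 4-cyanophenyl on an aromatic carbon. The step from compound 1 to compound 2 shows the distal substituent can move the number by a modest amount; with the nitrile gone, a lower number than that of compound 2 is expected, of size a 2.5-fold lower number from compound 2 to compound 4 (0.40 log units; beyond the scatter). Compound 4 is therefore estimated at 60 nM in this assay, with a range of 20 nM to 200 nM.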

Compound 4, half-maximal inhibitory concentration: 150 nM
Compound 4: middle estimate off by 2.5-fold (0.40 log units), on the low side; the range from low to high includes it.
By their numbers in this assay, from the lowest: compounds 3 and 1 (each within the scatter of the next); then compounds 2 and 4 (each within the scatter of the next).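

In this assay, the step with 2-fluoropyridin-4-yl in place of 4-cyanophenyl reads no change at the digits printed from compound 2 to compound 4 (within the scatter) and shows that a second, different distal ring gives the same number as the nitrile, so losing the nitrile does not by itself restore the number of compound 1. The step of a 6.0-fold higher number from compound 1 to compound 4 (0.78 log units; beyond the scatter) matches the earlier step of a 6.0-fold higher number from compound 1 to compound 2 (0.78 log units; beyond the scatter) in size, so at this position the 4-methoxyphenyl has now given a lower number than each of two different replacements. The data at hand offer nothing that accounts for this result.

Open, on these data alone, is whether the fluorine or the ring nitrogen of the new group matters, which an unsubstituted phenyl or a pyridine without fluorine at this place could separate. Also open, as far as these compounds go, is how an amine or a carboxylic acid on the distal ring would read in this assay against compound 1.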